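Series notes: ring size of the amine on compound 2

The source may report more compounds than this note shows. Statements on the series, on what has been measured and on what is new or still open speak of the compounds shown alone.

Going by the values given here, compound 2 `CN(C)[C@H]1CCN(c2cccc3c2C[C@H](CN(C)[C@H]2CCCc4cccnc42)NC3)C1` stands at the low end of the two numbers so far: in a functional assay on CCRF-CEM cells for antagonist activity at C-X-C chemokine receptor type 4 (Homo sapiens), read by calcium flux, with stated times of 25 min and 90 s (on this read-out higher numbers stand for weaker inhibition and lower numbers for stronger inhibition), compound 2 gives 10.9 nM, while compound 1 `CN(C[C@H]1Cc2c(cccc2N2CCC(N)CC2)CN1)[C@H]1CCCc2cccnc21` gives 33.4 nM. Among the compounds with values here, the one step measured, a 3.1-fold lower number from compound 1 to compound 2 (0.49 log units; beyond the scatter), is the only comparison in hand.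

Compound 3 `CN(C)C1CCN(c2cccc3c2C[C@H](CN(C)[C@H]2CCCc4cccnc42)NC3)CC1` is the next member. The change is 4-(dimethylamino)piperidin-1-yl in place of 3-(dimethylamino)pyrrolidin-1-yl on an aromatic carbon. Compared with the measured step, this move keeps the dimethylamino group of compound 2 but returns to the six-membered ring of compound 1, so it reverses only part of what a 3.1-fold lower number from compound 1 to compound 2 (0.49 log units; beyond the scatter) covered. That step was modest, and the present change is of similar reach, so the expectation is a step in this assay no larger than that, if any, and pointing back toward compound 1 rather than further down.

On this basis the step from compound 2 to compound 3 is estimated at a 1.7-fold higher number from compound 2 to compound 3 (0.22 log units; within the scatter), a change that may sit inside the scatter. Compound 3 is therefore expected to give 18 nM in this assay, with a likely range of 7 nM to 50 nM.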

Compound 3, half-maximal inhibitory concentration: 35.9 nM
The estimate for compound 3 lay 2.0-fold (0.30 log units) below the measured number; the range from low to high includes it.
By their numbers in this assay, from the lowest: compound 2; then compounds 1 and 3 (each within the scatter of the next).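

In this assay, going by these compounds alone, with the dimethylamino group held constant, 4-(dimethylamino)piperidin-1-yl in place of 3-(dimethylamino)pyrrolidin-1-yl on the aromatic carbon gives a 3.3-fold higher number from compound 2 to compound 3 (0.52 log units; beyond the scatter) and thus separates the ring change from the change of amine substitution for the first time. With the six-membered ring held constant, dimethylamino in place of amino on the saturated ring carbon gives a 1.1-fold higher number from compound 1 to compound 3 (0.03 log units; within the scatter) and leaves those two compounds indistinguishable on this read-out, so among these three compounds the only gaps beyond the scatter are those that involve the five-membered ring of compound 2.

The five-membered ring in compound 2 also carries a defined stereocentre, which the six-membered ring lacks, so ring size and stereochemistry remain confounded in this comparison and the opposite configuration at that carbon would be needed to separate them. On these data alone, it also remains open whether 3-aminopyrrolidin-1-yl, with a primary amine on the five-membered ring, would track compound 2, and whether a four-membered 3-(dimethylamino)azetidin-1-yl would extend the trend. No supporting evidence on why the five-membered ring gives the lower number is available here.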